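Small Phenyl Swaps and an Untested Hydroxy Group

The source may report more compounds than this note shows. Statements on the series, on what has been measured and on what is new or still open speak of the compounds shown alone.

Compound 1 `COc1cccc(/C=C2\CCC/C(=C\c3ccccc3Br)C2=O)c1OC`: 12100 nM
Compound 2 `COc1cccc(/C=C2\CCC/C(=C\c3cccc(OC)c3OC)C2=O)c1`: 7000 nM
Compound 3 `COc1ccc(/C=C2\CCC/C(=C\c3cccc(OC)c3OC)C2=O)cc1`: 13600 nM

All three values come from a functional assay on SW-620 cells (Homo sapiens) for cytotoxicity, read by MTT assay, with a stated time of 72 h; on this read-out higher numbers stand for weaker inhibition and lower numbers for stronger inhibition. Compound 3, at 13600 nM, stands within the scatter of both other compounds. The measured comparisons show a 1.1-fold higher number from compound 1 to compound 3 (0.05 log units; within the scatter) and a 1.9-fold higher number from compound 2 to compound 3 (0.29 log units; within the scatter).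

The next compound, compound 4 `COc1cccc(/C=C2\CCC/C(=C\c3ccc(O)cc3)C2=O)c1OC`, departs from compound 3 by one small change: hydrogen in place of methyl on an oxygen on an aromatic ring. In words, hydrogen takes the place of methyl on an oxygen on an aromatic ring, turning 4-methoxyphenyl into 4-hydroxyphenyl.

Going by the values given here, no measured compound carries a hydroxy group, so the data offer no direct test of this change. The nearest evidence is the set of steps that exchange one substituted phenyl group for another. Besides the two above, there is a 1.7-fold lower number from compound 1 to compound 2 (0.24 log units; within the scatter). Each of these steps stays within the scatter, including the one that replaces 3-methoxyphenyl with 4-methoxyphenyl. On that limited basis, no step beyond the scatter is expected in this assay, and no firm direction can be assigned.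

The estimated change is a 1.4-fold lower number from compound 3 to compound 4 (0.16 log units; within the scatter). The expected value for compound 4 is 9500 nM, with an estimated range of 3500 nM to 25000 nM.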

Compound 4, half-maximal inhibitory concentration: > 20000 nM
Compound 4 gave a limit, no number (the forecaster's own chance of this, stated with the estimate: 5%); middle value at least 2.1-fold (0.32 log units) from the limit.
By their numbers in this assay, from the lowest: compounds 2, 1 and 3 (each within the scatter of the next). At a limit, above all of these: compound 4.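

In this assay, compound 4 is read only as a limit, not a number: the limit of > 20000 nM in this assay, at which 1 of the 4 values shown sits.

This gives the series its first step beyond the scatter, an at least 2.8-fold higher number from compound 2 to compound 4 (0.45 log units; beyond the scatter), which shows that 4-hydroxyphenyl in place of 3-methoxyphenyl moves the read-out toward weaker inhibition. The other two steps are floors that lie within the scatter, an at least 1.4-fold higher number from compound 3 to compound 4 (0.16 log units; that floor lies within the scatter) and an at least 1.6-fold higher number from compound 1 to compound 4 (0.21 log units; that floor lies within the scatter), so the direction of the change from methyl to hydrogen on the oxygen is upward, but its size remains unsettled.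

The compounds shown leave open how far beyond its limit compound 4 really lies, and therefore whether the single exchange of methoxy for hydroxy is a small step or a large one. They also leave open whether an amine or a carboxylic acid in place of the hydroxy group of 4-hydroxyphenyl, on the same core, would give a measurable number in this assay.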